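Fluoro to hydrogen on compound 3: expected flat step

The source may report more compounds than this note shows. Statements on the series, on what has been measured and on what is new or still open speak of the compounds shown alone.

Measured in a functional assay on MGC-803 cells (Homo sapiens) for antiproliferative activity, read by MTT assay, with a stated time of 72 h; on this read-out lower numbers stand for stronger inhibition and higher numbers for weaker inhibition:
- compound 1 `Cc1ccccc1-n1nc(-c2ccccc2)nc1CNc1ccc(C(=O)NO)cc1` gives 12300 nM
- compound 2 `O=C(NO)c1ccc(NCc2nc(-c3ccc(F)cc3)nn2-c2ccccc2)cc1` gives 8960 nM
- compound 3 `O=C(NO)c1ccc(NCc2nc(-c3ccccc3)nn2-c2ccc(F)cc2)cc1` gives 10500 nM

Compound 3 lies within the scatter of both compound 1 and compound 2, so the three values do not separate. Compound 4 `O=C(NO)c1ccc(NCc2nc(-c3ccccc3)nn2-c2ccccc2)cc1` differs from compound 3 by hydrogen in place of fluoro on an aromatic carbon. For the measured compounds named here, only one measured step bears on this: a 1.2-fold lower number from compound 1 to compound 3 (0.07 log units; within the scatter), which stays within the scatter. No step beyond the scatter is therefore expected in this assay. For compound 4, the expected step is a 1.1-fold lower number from compound 3 to compound 4 (0.02 log units; within the scatter). Compound 4 is estimated at 10000 nM (5500 nM to 18000 nM).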

Compound 4, half-maximal inhibitory concentration: 17700 nM
Estimate against measurement, compound 4: 1.8-fold (0.25 log units) below; the measured number falls inside the stated range.
By their numbers in this assay, from the lowest: compounds 2, 3, 1 and 4 (each within the scatter of the next).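

In this assay hydrogen in place of fluoro gives a 1.7-fold higher number from compound 3 to compound 4 (0.23 log units; within the scatter) on the ring carried by the aromatic nitrogen and a 2.0-fold higher number from compound 2 to compound 4 (0.30 log units; within the scatter) on the other phenyl ring, so fluoro does not separate from hydrogen on either ring. Hydrogen in place of methyl on the ring carried by the aromatic nitrogen gives a 1.4-fold higher number from compound 1 to compound 4 (0.16 log units; within the scatter) and does not separate them either. Nothing measured on these compounds explains these small steps. Going by these compounds, an amine or a carboxylic acid para to a large group remains open, and so does whether any change on these rings moves the number beyond the scatter.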